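The source may report more compounds than this note shows. Statements on the series, on what has been measured and on what is new or still open speak of the compounds shown alone.

Measured in a functional assay (aorta) with Rattus norvegicus as the target; on this read-out higher numbers stand for an effect only at larger amounts of compound and lower numbers for an effect already at smaller amounts:
- compound 1 `O=C1CCCN1[C@@H]1c2cc([N+](=O)[O-])ccc2OC(CF)(CF)[C@H]1O`: 24 nM
- compound 2 `O=C1CCCN1[C@@H]1c2cc(C(F)(F)C(F)(F)F)ccc2OC(CF)(CF)[C@H]1O`: 6.31 nM
- compound 3 `N#Cc1ccc2c(c1)C(N1CCCC1=O)=CC(CF)(CF)O2`: 102 nM

Compound 3 carries the highest number of the three, beyond the scatter from both others. Compound 4 `O=C1CCCN1C1=CC(CF)(CF)Oc2ccc(C(F)(F)C(F)(F)F)cc21` has 1,1,2,2,2-pentafluoroethyl in place of cyano on an aromatic carbon. Going by the values given here, the only measured step with this entering group is a 3.8-fold lower number from compound 1 to compound 2 (0.58 log units; beyond the scatter). There nitro leaves rather than cyano, and the core of compound 1 differs from the core of compound 3, so this step is only an indirect guide. A modest move towards a lower number in this assay is expected, estimated as a 3.8-fold lower number from compound 3 to compound 4 (0.58 log units; beyond the scatter). For compound 4 the estimated value is 27 nM, with an expected range from 9 nM to 80 nM.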

Compound 4, half-maximal effective concentration: 1.51 nM
Estimate against measurement, compound 4: 18-fold (1.25 log units) above; measured number outside the range, below it.
By their numbers in this assay, from the lowest: compound 4; then compound 2; then compound 1; then compound 3.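

In this assay, 1,1,2,2,2-pentafluoroethyl in place of cyano on this aromatic carbon gives a large step (a 68-fold lower number from compound 3 to compound 4 (1.83 log units; beyond the scatter)), so this group also goes with a lower number on the core of compound 3, not only on the core of compound 1 (a 3.8-fold lower number from compound 1 to compound 2 (0.58 log units; beyond the scatter)). The step from cyano is the larger, but the leaving group and the core both differ between the two steps, so neither can be singled out. Nothing at hand explains its size. Open, from the compounds shown here alone, is how nitro and cyano compare on one core. Also open, going by these compounds, is where trifluoromethyl or an amine on this aromatic carbon would fall.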